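Replacing pyridin-3-yl with 3-nitrophenyl

The compounds below may be only part of what the source reports. "The series", "measured", "known", "first", "only" and "open" are said of these compounds alone.

Values in a physicochemical assay for lipophilicity, read by LC-MS, in phosphate buffer, measured as octanol-water partition, at pH 7.4, tested at 66.7 uM (on this read-out higher numbers stand for higher lipophilicity and lower numbers for lower lipophilicity), stand as follows:
Compound 1 `CN1CCN(c2ccc(Nc3nccc(-c4ccccc4)n3)cc2C(F)(F)F)CC1` gives 4.8
Compound 2 `CN1CCN(c2ccc(Nc3nccc(-c4ccc5ccccc5c4)n3)cc2C(F)(F)F)CC1` gives > 5.7 as a limit and not a number
Compound 3 `CN1CCN(c2ccc(Nc3nccc(-c4cccnc4)n3)cc2C(F)(F)F)CC1` gives 3.53

Compound 3 sits lowest, and its steps to both others lie beyond the scatter. Compound 4 `CN1CCN(c2ccc(Nc3nccc(-c4cccc([N+](=O)[O-])c4)n3)cc2C(F)(F)F)CC1` remains unmeasured. The change 3-nitrophenyl in place of pyridin-3-yl on an aromatic carbon puts 3-nitrophenyl in place of pyridin-3-yl on an aromatic carbon. The closest guide is the swap of phenyl for pyridin-3-yl, which gave a number 1.27 log units lower from compound 1 to compound 3 (beyond the scatter) and the swap from naphthalen-2-yl gave a number at least 2.17 log units lower from compound 2 to compound 3 (beyond the scatter) in the same direction. Within the data shown here, compound 4 regains an aromatic ring of carbon only, so a large rise is expected in this assay on the evidence of a number 1.27 log units lower from compound 1 to compound 3 (beyond the scatter) although no measured compound carries a nitro group. The expected change is a number 1.07 log units higher from compound 3 to compound 4 (beyond the scatter) on this reasoning. The estimated value for compound 4 is 4.6 with a range from 4 to 5.2 on this estimate.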

Compound 4, distribution coefficient: 4.5
Compound 4: the middle estimate sits 0.10 log units above what was measured; low and high end bracket the measured number.
By their numbers in this assay, from the lowest: compound 3; then compounds 4 and 1 (each within the scatter of the next). At a limit, above all of these: compound 2.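

In this assay, 3-nitrophenyl in place of pyridin-3-yl gives a number 0.97 log units higher from compound 3 to compound 4 (beyond the scatter) and so shows that a ring of carbon only at this position lifts the number even when it carries a nitro group. Nitro in place of hydrogen on the phenyl ring gives a number 0.30 log units lower from compound 1 to compound 4 (within the scatter) and leaves the two compounds indistinguishable. The comparison with naphthalen-2-yl gives a number at least 1.20 log units lower from compound 2 to compound 4 (beyond the scatter) but rests on a limit and not a number: the limit of > 5.7 in this assay, at which 1 of the 4 values shown sits. Going by these compounds, whether a nitrile or a carboxylic acid in place of the nitro group would read like compound 4 stays open.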